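The source may hold more compounds than are shown below. What is called first, only, known or untested is meant among the compounds shown, and "the series" means these compounds.

In a physicochemical assay for solubility, using the shake flask method, in phosphate buffer, measured as kinetic solubility, with a stated time of 20 h, at pH 6.5 (on this read-out lower numbers stand for lower solubility and higher numbers for higher solubility), three compounds on the shared core have been measured so far. Compound 1 `FC(F)(F)c1cccc(-c2nc3cnc(Nc4cnccn4)cc3[nH]2)c1` gives < 5000 nM, which is a limit of the assay and not a number. Compound 2 `Fc1ccc(-c2nc3cnc(Nc4ccc(C(F)(F)F)cn4)cc3[nH]2)cc1F` gives < 5000 nM, which is also only a limit. Going by the values given here, compound 3 `FC(F)(F)c1ccc(Nc2cc3[nH]c(C4CCCC4)nc3cn2)nc1` gives 145000 nM, the only true number of the three. Compound 4 `FC(F)(F)c1ccc(Nc2cc3[nH]c(C4CCOC4)nc3cn2)nc1` has oxolan-3-yl in place of cyclopentyl on an aromatic carbon. Among the compounds with values here, the one measured step at this place is an at least 29-fold higher number from compound 2 to compound 3 (1.46 log units; beyond the scatter), with cyclopentyl in place of 3,4-difluorophenyl. That step exchanged an aromatic group for a non-aromatic ring, whereas a five-membered non-aromatic ring stays in the present change, so a step of that large size is not expected in this assay. A small rise at most, not clearly beyond the scatter, is expected: a 1.6-fold higher number from compound 3 to compound 4 (0.20 log units; within the scatter). For compound 4 the estimated value is 230000 nM, with an expected range from 110000 nM to 480000 nM.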

Compound 4, solubility: 166000 nM
The estimate for compound 4 lay 1.4-fold (0.14 log units) above the measured number, and the stated range covers the measured number.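

In this assay, exchanging cyclopentyl for oxolan-3-yl on the aromatic carbon between two ring nitrogen atoms gives a 1.1-fold higher number from compound 3 to compound 4 (0.06 log units; within the scatter), so the hydrogen-bond acceptor that enters with oxolan-3-yl goes with no change beyond the scatter, something compound 3 alone could not show. A second non-aromatic five-membered ring also gives an at least 33-fold higher number from compound 2 to compound 4 (1.52 log units; beyond the scatter), so the large step away from 3,4-difluorophenyl now appears with two different rings, compound 3 and compound 4. The size of these steps remains open-ended, since compound 2 stands only at a limit and not at a number: the limit of < 5000 nM in this assay, at which 2 of the 4 values shown sit.

What the compounds shown leave open is how an amine or a carboxylic acid on this ring would read in this assay. Also open, from the compounds shown here alone, is whether an open alkyl chain at this place would read like the two rings.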